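This account rests on a few compounds, and the source may have more. Where it says the series, first, only, none or still open, it means among the compounds named here.

Measured so far:
compound 1 `O=c1cc(NC2CC2)cc(-c2ccccc2)o1` — > 30 uM
compound 2 `COc1ccc(Nc2cc(C)oc(=O)c2)cc1` — > 30 uM
compound 3 `Cc1ccc(Nc2cc(-c3ccccc3)oc(=O)c2)cc1` — 0.067 uM

Of the compounds shown here, three on a shared core have been tested in a functional assay on A549 cells (Homo sapiens) for cytotoxicity, read by MTT assay, with a stated time of 72 h; on this read-out lower numbers stand for an effect already at smaller amounts and higher numbers for an effect only at larger amounts of compound. Compound 1 `O=c1cc(NC2CC2)cc(-c2ccccc2)o1` reaches only the limit of the assay, > 30 uM, not a number. Compound 2 `COc1ccc(Nc2cc(C)oc(=O)c2)cc1` likewise gives only the limit, > 30 uM. Compound 3 `Cc1ccc(Nc2cc(-c3ccccc3)oc(=O)c2)cc1` gives a number, 0.067 uM. Going by the values given here, the one step that can be counted, an at least 440-fold lower number from compound 1 to compound 3 (2.65 log units; beyond the scatter), is large; it sits at the limit of > 30 uM in this assay, at which 2 of the 3 values shown sit, so its true size is unknown beyond that floor. Compound 2 therefore stands at the limit, alongside compound 1, while compound 3 stands well away from it.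

Compound 4 `COc1ccc(Nc2cc(C(C)C)oc(=O)c2)cc1` has not been measured. It differs from compound 2 by isopropyl in place of methyl on an aromatic carbon. Among the compounds with values here, no measured step touches this position of the core: the only counted step concerns the group on the nitrogen, and compound 2 and compound 3 differ in two places at once, so their two values show only that one is a limit and the other is not. With nothing to point the way, the change is expected to stay within the scatter, a number no higher from compound 2 to compound 4 (the limit leaves the size open), and compound 4 is estimated at 30 uM, between 8 uM and 100 uM, most likely again reported as a limit.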

Compound 4, concentration for half-maximal effect: > 30 uM
Compound 4 ended at the assay's limit; the forecaster's own chance of this, stated with the estimate: 65%; the middle value sits exactly at the limit.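

Compound 2 and compound 4 both stop at the assay's limit rather than giving a number, so no step between them can be read: the limit of > 30 uM in this assay, at which 3 of the 4 values shown sit.

The compounds shown leave open whether isopropyl in place of methyl on an aromatic carbon changes the effect at all, and whether a change at that place would show on a compound that gives a number, such as compound 3.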